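The source may report more compounds than this note shows. Statements on the series, on what has been measured and on what is new or still open speak of the compounds shown alone.

Among the compounds measured so far, compound 3 `CC(=O)OC[C@H]1O[C@@H](n2cc(CN3C(=O)/C(=C\c4ccc(C)cc4)c4ccccc43)nn2)[C@H](OC(C)=O)[C@@H](OC(C)=O)[C@@H]1OC(C)=O` gives the lowest number: in an ADME assay on NIH3T3 cells (Homo sapiens) for cytotoxicity, read by sulforhodamine B assay, with a stated time of 48 h (a higher number here means a weaker inhibitor, a lower number a stronger inhibitor), compound 3 gives 9000 nM. Its nearest neighbour, compound 2 `CC(=O)OC[C@H]1O[C@@H](n2cc(CN3C(=O)/C(=C/c4ccc(C)cc4)c4ccccc43)nn2)[C@H](OC(C)=O)[C@@H](OC(C)=O)[C@@H]1OC(C)=O`, gives 73300 nM in this assay. Compound 1 `CC(=O)OC[C@H]1O[C@@H](n2cc(CN3C(=O)/C(=C/c4ccccc4)c4ccccc43)nn2)[C@H](OC(C)=O)[C@@H](OC(C)=O)[C@@H]1OC(C)=O` is reported only as a limit, > 100000 nM, and not as a number (the limit of > 100000 nM in this assay, at which 1 of the 3 values shown sits). The unmeasured compound 4 `CC(=O)OC[C@H]1O[C@@H](n2cc(CN3C(=O)/C(=C\c4ccc5ccccc5c4)c4ccccc43)nn2)[C@H](OC(C)=O)[C@@H](OC(C)=O)[C@@H]1OC(C)=O` differs from compound 3 by naphthalen-2-yl in place of 4-methylphenyl on a double-bonded chain carbon bound to a double-bonded ring carbon. Two measured steps are available. For the measured compounds named here, the step of an at least 1.3-fold lower number from compound 1 to compound 2 (0.13 log units; that floor lies within the scatter) is the only one that alters the group on the double-bonded chain carbon, and it is small. The step of an 8.1-fold lower number from compound 2 to compound 3 (0.91 log units; beyond the scatter) is larger, but it rests on configuration alone the fact that compounds 2 and 3 differ only in the configuration as drawn and leaves the aromatic group untouched. Neither step speaks directly to the exchange of 4-methylphenyl for naphthalen-2-yl, so the change from compound 3 to compound 4 is expected to stay near the scatter, no change at the digits printed from compound 3 to compound 4 (within the scatter). In this assay compound 4 is therefore estimated at 9000 nM, within a range from 3000 nM to 30000 nM.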

Compound 4, half-maximal inhibitory concentration: 80000 nM
Compound 4: middle estimate off by 8.9-fold (0.95 log units), on the low side; measured number outside the range, above it.
By their numbers in this assay, from the lowest: compound 3; then compounds 2 and 4 (each within the scatter of the next). At a limit, above all of these: compound 1.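

In this assay, the group on this double-bonded chain carbon proves to matter in its own right: exchanging 4-methylphenyl for naphthalen-2-yl, with the double bond drawn the same way, gives an 8.9-fold higher number from compound 3 to compound 4 (0.95 log units; beyond the scatter). For the compounds shown here, the only earlier change to this group, an at least 1.3-fold lower number from compound 1 to compound 2 (0.13 log units; that floor lies within the scatter), could not show this, and the only earlier step beyond the scatter, an 8.1-fold lower number from compound 2 to compound 3 (0.91 log units; beyond the scatter), changed configuration alone. The compounds shown offer no measured property that accounts for this rise.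

Going by these compounds, it remains open whether the rise follows from the second aromatic ring or is specific to naphthalen-2-yl, which a single exchange cannot separate. Also open, on these data alone, is how a 4-methoxyphenyl or 4-aminophenyl group at this place would read, and whether naphthalen-2-yl would give the same result with the double bond drawn the other way.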